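The source may hold more compounds than are shown below. What is called first, only, known or untested is meant among the compounds shown, and "the series" means these compounds.

In an ADME assay on HeLa cells (Homo sapiens) for cytotoxicity, read by MTT assay (a higher number here means that more compound is tolerated, a lower number that less compound is tolerated), compound 3 `Cc1nc(-c2cccnc2)sc1-c1nnc(-c2ccccc2)o1` stands at > 100 ug/mL and this is a limit, not a number. Compound 1 `Cc1nc(-c2cccnc2)sc1-c1nnc(Cc2ccccc2)o1` reads > 100 ug/mL and this too is a limit. Compound 2 `Cc1nc(-c2cccnc2)sc1-c1nnc(-c2ccc([N+](=O)[O-])cc2)o1` reads > 100 ug/mL and this is also a limit. The evidence so far is thus the limit of > 100 ug/mL in this assay, at which 3 of the 3 values shown sit, and nothing finer. Compound 4 `Cc1ccc(-c2nnc(-c3sc(-c4cccnc4)nc3C)o2)cc1` puts methyl in place of hydrogen on an aromatic carbon and nothing else changes. The two measured steps bearing on it are a step that the two limits leave unreadable from compound 1 to compound 3 and a step that the two limits leave unreadable from compound 2 to compound 3 and with neither readable, no step beyond the scatter is expected in this assay either way. As far as these compounds go, the estimated step is a step that the limit leaves unreadable from compound 3 to compound 4 and its direction stays open. For compound 4 the expected value is 120 ug/mL within an estimated range of 60 ug/mL to 250 ug/mL in all.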

Compound 4, half-maximal cytotoxic concentration: > 100 ug/mL
Compound 4: only a limit was reported (the forecaster's own chance of this, stated with the estimate: 85%); the middle value is on the limit's open side.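

Compound 4 also gives only a limit, so no step can be read between it and compound 1, compound 2 or compound 3 in this assay. The compounds shown leave open how the four differ, if they do, in tolerated concentration: the limit of > 100 ug/mL in this assay, at which 4 of the 4 values shown sit.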